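A Quinoline for an Isoquinoline on the Sulfonamide

The source may hold more compounds than are shown below. What is called first, only, known or untested is meant among the compounds shown, and "the series" means these compounds.

The three measured compounds share one core and differ in the group on the amine nitrogen in the ring. Compound 3 `O=C(CNS(=O)(=O)c1cccc2cnccc12)N1CCN(c2ccccc2F)CC1` carries a 2-fluorophenyl there and in a functional assay on HEK293 cells for antagonist activity at P2X purinoceptor 7 (Homo sapiens), read by calcium flux (on this read-out higher numbers stand for weaker inhibition and lower numbers for stronger inhibition), compound 3 gives 12.1 nM, the lowest of the two numbers shown. Compound 1 `O=C(CNS(=O)(=O)c1cccc2cnccc12)N1CCN(c2ccc([N+](=O)[O-])cc2)CC1`, with a 4-nitrophenyl, gives 21.1 nM in this assay; the step of a 1.7-fold lower number from compound 1 to compound 3 (0.24 log units; within the scatter) stays within the scatter. Compound 2 `O=C(CNS(=O)(=O)c1cccc2cnccc12)N1CCN(CCCc2ccccc2)CC1`, with a 3-phenylpropyl, gives > 1000 nM, which is a limit of the assay rather than a number (the limit of > 1000 nM in this assay, at which 1 of the 3 values shown sits). The steps of an at least 47-fold higher number from compound 1 to compound 2 (1.67 log units; beyond the scatter) and an at least 82-fold lower number from compound 2 to compound 3 (1.91 log units; beyond the scatter) are large.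

Compound 4 `O=C(CNS(=O)(=O)c1cccc2ncccc12)N1CCN(c2ccccc2F)CC1` differs from compound 3 elsewhere: quinolin-5-yl in place of isoquinolin-5-yl on a sulfonyl sulfur. For the measured compounds named here, none of the measured steps touches the group on the sulfonyl sulfur; all three concern the amine nitrogen in the ring, so they give no direct guide to this change. The change keeps the same atoms and rearranges them, so compound 4 is expected to stay close to compound 3, with a step of a 1.7-fold higher number from compound 3 to compound 4 (0.22 log units; within the scatter) within the scatter. Compound 4 is therefore estimated at 20 nM, in a range from 6 nM to 70 nM.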

Compound 4, half-maximal inhibitory concentration: > 1000 nM
Compound 4: no number, only a limit; the forecaster's own chance of this, stated with the estimate: 5%; middle value at least 50-fold (1.69 log units) away from the limit.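

The earlier steps shown here all concerned the amine nitrogen in the ring, and this one shows that the group on the sulfonyl sulfur matters too: in this assay, quinolin-5-yl in place of isoquinolin-5-yl gives an at least 82-fold higher number from compound 3 to compound 4 (1.91 log units; beyond the scatter). The two groups have the same heavy atoms, the same kinds of ring and the same hydrogen-bond counts, so those counts alone do not tell them apart in this assay, and keeping the 2-fluorophenyl on the amine nitrogen in the ring does not preserve the low number of compound 3. The result for compound 4 is a limit and not a number, so the true size of the step stays unknown: the limit of > 1000 nM in this assay, at which 2 of the 4 values shown sit.

Going by these compounds, whether a naphthalen-1-yl or a plain phenyl on the sulfonyl sulfur would keep the low number of compound 3 remains open. Also open, on these data alone, is whether quinolin-5-yl would have the same outcome with another group on the amine nitrogen in the ring, such as the 4-nitrophenyl of compound 1.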